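Phenyl in Place of Hydrogen: Expecting Compound 4

The source may hold more compounds than are shown below. What is called first, only, known or untested is meant among the compounds shown, and "the series" means these compounds.

Compound 3 `COC(=O)C1=C(C)NC(=S)NC1c1ccoc1` was tested in an assay on membranes from HeLa cells for displacement of a labelled ligand from adenosine receptor A3 (Homo sapiens), read by scintillation counting, with a stated time of 180 min, tested at 1 uM (a higher number here means more inhibition at the concentration tested (going by the name of the read-out), a lower number less inhibition), and gave 3%. Among the three numbers recorded so far, compound 3 sits second of three, though every gap is within the scatter: its nearest neighbour is compound 2 `CC1=C(C(=O)OC(C)C)[C@H](c2ccco2)NC(=S)N1`, which gave 2%, and the furthest is compound 1 `CCCOC(=O)C1=C(C)NC(=O)NC1c1ccsc1`, which gave 6%. Compound 4 `CC1=C(C(=O)OCc2ccccc2)C(c2ccoc2)NC(=S)N1` has not yet been measured. It differs from compound 3 by phenyl in place of hydrogen on a saturated chain carbon bound to an oxygen next to a carbonyl group, a change that the data do not pair with any measured step, and with all recorded numbers near the floor, the expected step is none beyond the scatter, so a number 3 percentage points higher from compound 3 to compound 4 (within the scatter) is the estimated shift. Compound 4 is estimated to give 6%, within 0% to 18%.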

Compound 4, a percentage reported as inhibition, at one concentration (the size of the read-out at that concentration, not a potency): 20%
Estimate against measurement, compound 4: 14 percentage points below; the whole stated range lies below it.
By their numbers in this assay, from the lowest: compounds 2, 3 and 1 (each within the scatter of the next); then compound 4.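

In this assay, phenyl in place of hydrogen on a saturated chain carbon bound to an oxygen next to a carbonyl group gives a number 17 percentage points higher from compound 3 to compound 4 (beyond the scatter), the first step shown to lie beyond the scatter. This position is therefore the first shown to respond to a change, here methyl to benzyl. Nothing at hand accounts for the rise.

As far as these compounds go, whether phenethyl, a longer chain, or cyclohexyl in place of phenyl would keep this gain remains open. So does whether benzyl would give a similar step on compound 1 or compound 2.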